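The compounds below may be only part of what the source reports. "The series", "measured", "known", "first", "only" and "open" are said of these compounds alone.

Measured in a functional assay on MCF7 cells (Homo sapiens) for inhibition, read by sulforhodamine B assay; on this read-out lower numbers stand for stronger inhibition of growth and higher numbers for weaker inhibition of growth:
compound 1 `CC1(C)CCC[C@]2(C)[C@@H](/C=C/C3=CCOC3=O)C(C=O)=CC(=O)[C@@H]12`: 69900 nM
compound 2 `CC1(C)CCC[C@]2(C)[C@@H](/C=C/C3=CC(=O)OC3)C(CO)=C(O)C(=O)[C@@H]12`: 12000 nM
compound 3 `CC1=CC(=O)[C@H]2C(C)(C)CCC[C@]2(C)[C@H]1/C=C/c1ccoc1`: 14900 nM

Among these three, compound 3 at 14900 nM lies within the scatter of compound 2 at 12000 nM. Compound 1 at 69900 nM shows a higher number than compound 3, a gap beyond the scatter, and so weaker inhibition of growth.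

The next compound is compound 4 `CC1=CC(=O)[C@H]2C(C)(C)CCC[C@]2(C)[C@H]1/C=C/C1=CCOC1=O`. It keeps the core of compound 3, but the furan-3-yl, on a double-bonded chain carbon bound to a double-bonded chain carbon, gives way to a group with one five-membered non-aromatic ring with 1 hetero atom: a group of 6 heavy atoms (4 carbon, 2 oxygen; one five-membered non-aromatic ring with 1 hetero atom) in place of a group of 5 heavy atoms (4 carbon, 1 oxygen; one five-membered aromatic ring with 1 hetero atom), on a double-bonded chain carbon bound to a double-bonded chain carbon.

Going by the values given here, no measured pair of compounds differs in one place, so the size of this step cannot be read directly from the data. A small step towards weaker inhibition in this assay is expected, perhaps no larger than the scatter, because compound 1 with the entering group gives 69900 nM. That hint is limited, since compound 1 also differs elsewhere in the core.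

The expected change is a 1.7-fold higher number from compound 3 to compound 4 (0.22 log units; within the scatter). For compound 4 the estimated value is 25000 nM, with an expected range from 9000 nM to 70000 nM.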

Compound 4, concentration for 50% growth inhibition: 15700 nM
The estimate for compound 4 lay 1.6-fold (0.20 log units) above the measured number, within the range that was stated.
By their numbers in this assay, from the lowest: compounds 2, 3 and 4 (each within the scatter of the next); then compound 1.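

In this assay, the exchange of furan-3-yl for the group with one five-membered non-aromatic ring, on a double-bonded chain carbon bound to a double-bonded chain carbon, gives a 1.1-fold higher number from compound 3 to compound 4 (0.02 log units; within the scatter), so with this core the two groups cannot be told apart at this position. Going by these compounds alone, the other new step, methyl in place of formyl on a double-bonded ring carbon, gives a 4.5-fold lower number from compound 1 to compound 4 (0.65 log units; beyond the scatter), and it is the first change in a single place to show a difference beyond the scatter, placing the gap that earlier could only be seen across compounds differing in more than one place at this ring substituent. Nothing measured here accounts for either result.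

Within the data shown here, whether the methyl and formyl exchange has the same size with furan-3-yl on the chain remains open, and compound 2 still differs from the others in more than one place, so no step to it can be read. Also open, as far as these compounds go, is what a carboxylic acid or an amine on the double-bonded ring carbon, or a phenyl ring on the chain, would give in this assay.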